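Swapping Selenium for Methylsulfanyl on a Weakly Active Core

The source may hold more compounds than are shown below. What is called first, only, known or untested is meant among the compounds shown, and "the series" means these compounds.

Three compounds have been measured in a functional assay on MCF7 cells (Homo sapiens) for cytotoxicity, read by MTT assay, with a stated time of 72 h; on this read-out higher numbers stand for weaker inhibition of growth and lower numbers for stronger inhibition of growth:

Compound 1 `[SeH]c1nc(NCc2ccccc2)c2cccnc2n1`: > 100000 nM
Compound 2 `CSc1nc(NCc2ccccc2)c2ccccc2n1`: 82800 nM
Compound 3 `CCCCCSc1nc(O)c2ccccc2n1`: 81400 nM

Compound 1 stands at the edge of what this assay can report. For compound 1 the value > 100000 nM is a limit of the assay and not a number, the point (the limit of > 100000 nM in this assay, at which 1 of the 3 values shown sits). Compound 2 gives 82800 nM and compound 3 gives 81400 nM; both are numbers near the weak end of the scale.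

Compound 4 `CSc1nc(NCc2ccccc2)c2cccnc2n1` is not yet measured. It differs from compound 1 in one place: a group of 2 heavy atoms (1 carbon, 1 sulfur; no ring) in place of one selenium atom, on an aromatic carbon, on the shared core of compound 1. Among the measured compounds shown here, no measured pair shows this change, so the size of the step is only an expectation. Compound 2, which also carries a methylsulfanyl group, gives 82800 nM. Compound 1 itself sits at a limit. On that basis the step from compound 1 to compound 4 is expected to be small, an at least 1.1-fold lower number from compound 1 to compound 4 (0.04 log units; that floor lies within the scatter), not clearly beyond the scatter. Compound 4 is therefore expected to give about 90000 nM, within a range from 40000 nM to 200000 nM, with a fair chance that this assay again reports only a limit.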

Compound 4, concentration for total growth inhibition: > 100000 nM
Compound 4: no number, only a limit; the forecaster's own chance of this, stated with the estimate: 45%; middle value at least 1.1-fold (0.04 log units) from the limit.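

Compound 1 and compound 4 both sit at a limit and give no number, so no step between them can be read: the limit of > 100000 nM in this assay, at which 2 of the 4 values shown sit.

The compounds shown leave open whether methylsulfanyl in place of the selenium atom changes growth inhibition at all on the shared core, and by how much.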